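The compounds below may be only part of what the source reports. "The series", "measured", "known", "first", "only" and "open" are said of these compounds alone.

Measured so far:
- compound 1, `CC1=C(C(=O)Nc2ccc(Br)cc2)C(c2ccc(Cl)cc2Cl)N=C(SCc2ccc(Cl)cc2)N1`: 30.3%
- compound 2, `CC1=C(C(=O)Nc2ccc([N+](=O)[O-])cc2)C(c2ccc(Br)cc2)N=C(SCc2ccccc2Cl)N1`: 9.7%

Two compounds have been run in a functional assay on the whole organism (artery, strain albino) with Rattus norvegicus as the target, with a stated time of 600 min, at a dose of 10 mg/kg by the oral route; a higher number here means more inhibition at the dose given (going by the name of the read-out), a lower number less inhibition. Compound 1 gives 30.3% in this assay, and compound 2 gives 9.7%. Compound 2 therefore stands lowest of the two numbers; its nearest neighbour is compound 1, which lies higher by a gap beyond the usual scatter. Among the compounds with values here, the two differ in several places at once, so no single step between them can be read.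

The next compound, compound 3, `CC1=C(C(=O)Nc2ccc([N+](=O)[O-])cc2)C(c2ccc(Br)cc2)N=C(SCc2ccc(F)cc2)N1`, differs from compound 2 in one place only: 4-fluorophenyl in place of 2-chlorophenyl on a saturated chain carbon bound to a sulfur. Within the data shown here, no step of this kind between measured compounds exists in the data, so the size of the change in this assay has no direct precedent. The expectation is a small upward step, a number 5.3 percentage points higher from compound 2 to compound 3 (within the scatter), of a size that does not clearly exceed the scatter. Compound 3 is estimated at 15% in this assay, with a range from 0% to 35%.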

Compound 3, a percentage reported as inhibition, in the whole organism at one dose (the size of the read-out at that dose, not a potency): 32.3%
Beside the measured number, compound 3's estimate is 17.3 percentage points below it; the range from low to high includes it.
By their numbers in this assay, from the lowest: compound 2; then compounds 1 and 3 (each within the scatter of the next).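

In this assay, within the data shown here, the group on the saturated chain carbon bound to a sulfur proves to be a position that moves the read-out: 4-fluorophenyl in place of 2-chlorophenyl gives a number 22.6 percentage points higher from compound 2 to compound 3 (beyond the scatter), the first change that can be read at a single place. The rest of the molecule is the same in both compounds, so this step belongs to the exchange of these two aryl groups alone, although that exchange alters both the halogen and where it sits on the ring, and the step cannot divide its size between the two. Nothing at hand accounts for the size or direction of the step.

As far as these compounds go, whether the halogen matters more than its place stays open, and 2-fluorophenyl on this same carbon, with the rest of compound 2 unchanged, would separate the two. Also open is whether a halogen is needed at all, which an unsubstituted phenyl or a pyridine ring at this place would address, and a read-out at one dose and one time gives no potency for any of these compounds.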